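This account rests on a few compounds, and the source may have more. Where it says the series, first, only, none or still open, it means among the compounds named here.

The series shares one core; compound 1 `COc1cc(-c2nnc(SCC(=O)c3ccccc3)n2N)cc(OC)c1OC` carries a phenyl on the carbonyl carbon. In a functional assay on HepG2 cells (Homo sapiens) for antiproliferative activity, read by MTT assay, with a stated time of 48 h (a lower number here means a stronger inhibitor, a higher number a weaker inhibitor), compound 1 gives 7800 nM. Compound 2 `COc1cc(-c2nnc(SCC(=O)c3cccc(Br)c3)n2N)cc(OC)c1OC` gives 56000 nM in this assay. Compound 3 `COc1cc(-c2nnc(SCC(=O)Nc3ccc(C)cc3)n2N)cc(OC)c1OC` is reported in this assay only as a limit, > 100000 nM; (the limit of > 100000 nM in this assay, at which 1 of the 3 values shown sits). Among the numbers shown compound 1 stands lowest, with compound 2 nearest: a 7.2-fold higher number from compound 1 to compound 2 (0.86 log units; beyond the scatter). Compound 4 `COc1cc(-c2nnc(SCC(=O)NCc3ccc(Cl)cc3)n2N)cc(OC)c1OC` is not yet measured. It differs from compound 1 in one place: (4-chlorobenzyl)amino in place of phenyl on a carbonyl carbon. The step that bears on it most is the exchange of the phenyl ketone for an aryl amino group on the carbonyl carbon, an at least 12-fold higher number from compound 1 to compound 3 (1.10 log units; beyond the scatter), a large loss that runs into the limit; the comparison an at least 1.7-fold higher number from compound 2 to compound 3 (0.25 log units; that floor lies within the scatter) has a floor within the scatter and adds little. The change to compound 4 likewise places an amino group on the carbonyl carbon, here (4-chlorobenzyl)amino in place of phenyl, so a weakening step of roughly the size seen for compound 3 > 100000 nM is expected. Compound 4 is therefore expected to give 90000 nM in this assay, between 20000 nM and 300000 nM. That expectation means a 12-fold higher number from compound 1 to compound 4 (1.06 log units; beyond the scatter). A reported limit rather than a number is a real possibility.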

Compound 4, half-maximal inhibitory concentration: > 100000 nM
Compound 4 ended at the assay's limit; the forecaster's own chance of this, stated with the estimate: 55%; at least 1.1-fold (0.04 log units) between middle value and limit.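

In this assay, phenyl on the carbonyl carbon gives way to (4-chlorobenzyl)amino with an at least 12-fold higher number from compound 1 to compound 4 (1.10 log units; beyond the scatter), so a second amino group at this place, with a different group on its nitrogen, also falls beyond the scatter from compound 1, as the (4-methylphenyl)amino of compound 3 did. The comparison with the bromo ketone adds little, with an at least 1.7-fold higher number from compound 2 to compound 4 (0.25 log units; that floor lies within the scatter). Compound 3 and compound 4 are both reported only as limits, so the step between them cannot be read and the two amino groups cannot be ranked against each other: the limit of > 100000 nM in this assay, at which 2 of the 4 values shown sit.

The compounds shown leave open whether an unsubstituted amino group or a short alkylamino group on the carbonyl carbon would return a measured number in this assay, and so whether the loss follows the amide nitrogen itself or the aromatic groups it carries. Also open, from the compounds shown here alone, is whether a fluoro or methoxy group on the phenyl ketone of compound 1 would raise the number as the bromo of compound 2 does.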